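The source may report more compounds than this note shows. Statements on the series, on what has been measured and on what is new or still open speak of the compounds shown alone.

Three compounds share one core and differ only in the group attached to a carbonyl carbon on a side chain. In a functional assay on U2OS cells for antagonist activity at proto-oncogene Wnt-3 (Homo sapiens), read by a luciferase reporter, with a stated time of 18 h (on this read-out lower numbers stand for an effect already at smaller amounts and higher numbers for an effect only at larger amounts of compound), compound 1 `O=C(CN1CCNCC1)N1CCC(NS(=O)(=O)c2cc(S(=O)(=O)c3ccccc3)ccc2C(F)(F)F)CC1` gives 250 nM. In this assay compound 2 `O=C(Cn1ccnc1)N1CCC(NS(=O)(=O)c2cc(S(=O)(=O)c3ccccc3)ccc2C(F)(F)F)CC1` gives 230 nM, and compound 3 `CC(C)(C)OC(=O)N1CCC[C@@H]1C(=O)N1CCC(NS(=O)(=O)c2cc(S(=O)(=O)c3ccccc3)ccc2C(F)(F)F)CC1` gives 210 nM. Among the three numbers the one of compound 3 is the lowest as written, yet the steps of a 1.2-fold lower number from compound 1 to compound 3 (0.08 log units; within the scatter) and a 1.1-fold lower number from compound 2 to compound 3 (0.04 log units; within the scatter) both lie within the scatter, so the three compounds cannot be told apart on these data.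

Compound 4 `O=C1CC[C@@H](C(=O)N2CCC(NS(=O)(=O)c3cc(S(=O)(=O)c4ccccc4)ccc3C(F)(F)F)CC2)N1` is the next compound to be measured. The change from compound 3 is 5-oxopyrrolidin-2-yl in place of 1-(tert-butoxycarbonyl)pyrrolidin-2-yl on a carbonyl carbon. The measured steps that bear on this are the three changes made at the same carbonyl carbon: a 1.1-fold lower number from compound 1 to compound 2 (0.04 log units; within the scatter), a 1.2-fold lower number from compound 1 to compound 3 (0.08 log units; within the scatter) and a 1.1-fold lower number from compound 2 to compound 3 (0.04 log units; within the scatter). Every one of them stayed within the scatter although the groups exchanged differed widely in size and in ring type. On this basis the step to compound 4 is expected to be of the same kind, a 1.1-fold higher number from compound 3 to compound 4 (0.06 log units; within the scatter), with no direction that could be trusted beyond the scatter. The estimate for compound 4 in this assay is therefore 240 nM, with a range from 100 nM to 600 nM.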

Compound 4, half-maximal effective concentration: 240 nM
Compound 4: the middle estimate sits on the measured number at the digits printed; measured number inside the range.
By their numbers in this assay, from the lowest: compounds 3, 2, 4 and 1 (each within the scatter of the next).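

In this assay the change from compound 3 removes 1-(tert-butoxycarbonyl)pyrrolidin-2-yl, which has 12 heavy atoms and 0 hydrogen-bond donors, and brings in 5-oxopyrrolidin-2-yl, which has 6 heavy atoms and 1 hydrogen-bond donor, yet the result is only a 1.1-fold higher number from compound 3 to compound 4 (0.06 log units; within the scatter) and stays level with the bulkier group. The new group also matches the two earlier groups of a different shape: replacing (1H-imidazol-1-yl)methyl gives a 1.0-fold higher number from compound 2 to compound 4 (0.02 log units; within the scatter) and replacing (piperazin-1-yl)methyl gives a 1.0-fold lower number from compound 1 to compound 4 (0.02 log units; within the scatter) in the same assay. Across these four compounds, then, a much smaller group on this carbonyl carbon, and one that adds a hydrogen-bond donor, still leaves the number where it was, so neither difference shows up in this read-out.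

Nothing available explains why these four groups give such similar numbers. Still open, on these data alone, is whether any group on this carbonyl carbon can move the number beyond the scatter, for example a carboxylic acid, a primary amine or a longer alkyl chain, and whether the mirror-image form of 5-oxopyrrolidin-2-yl behaves the same way.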